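Oxetane to Acetylazetidine on the Ring Nitrogen

The source may report more compounds than this note shows. Statements on the series, on what has been measured and on what is new or still open speak of the compounds shown alone.

Measured compounds:
compound 1 `COc1cc2[nH]c(=O)[nH]c2cc1NS(=O)(=O)c1cccc(Cl)c1Cl` — 316 nM
compound 2 `COc1cc2c(cc1NS(=O)(=O)c1cccc(Cl)c1Cl)[nH]c(=O)n2CC(N)=O` — 457 nM
compound 3 `COc1cc2c(cc1NS(=O)(=O)c1cccc(Cl)c1Cl)[nH]c(=O)n2C1COC1` — 112 nM

In a functional assay on CHO cells for antagonist activity at C-C chemokine receptor type 4 (Homo sapiens), read by radioligand binding and GTPgammaS binding (a higher number here means a weaker inhibitor, a lower number a stronger inhibitor), compound 3 gives the lowest number of the three, and its steps to both other compounds lie beyond the scatter, so it is the strongest inhibitor among them. Compound 4 `COc1cc2c(cc1NS(=O)(=O)c1cccc(Cl)c1Cl)[nH]c(=O)n2C1CN(C(C)=O)C1` differs from compound 3 in one place: 1-acetylazetidin-3-yl in place of oxetan-3-yl on an aromatic nitrogen. Within the data shown here, two measured steps bear on this position. The step of a 2.8-fold lower number from compound 1 to compound 3 (0.45 log units; beyond the scatter) and the step of a 4.1-fold lower number from compound 2 to compound 3 (0.61 log units; beyond the scatter) both show that putting oxetan-3-yl on this nitrogen lowers the number by a modest amount, while the step of a 1.4-fold higher number from compound 1 to compound 2 (0.16 log units; within the scatter) shows carbamoylmethyl there changes little. Among the measured compounds shown here, no measured pair compares 1-acetylazetidin-3-yl with oxetan-3-yl, so the size of the new step is uncertain. The group entering keeps a four-membered ring with one hetero atom, so the account expects compound 4 to sit near compound 3, with a step of a 1.3-fold higher number from compound 3 to compound 4 (0.13 log units; within the scatter) that may stay within the scatter. For compound 4 the estimate in this assay is 150 nM, between 60 nM and 400 nM.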

Compound 4, half-maximal inhibitory concentration: 200 nM
Compound 4: the middle estimate sits 1.3-fold (0.12 log units) below what was measured; the measured number falls inside the stated range.
By their numbers in this assay, from the lowest: compounds 3, 4, 1 and 2 (each within the scatter of the next, the first and the last beyond it).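

In this assay, this aromatic nitrogen takes 1-acetylazetidin-3-yl, with 7 heavy atoms against the 4 of oxetan-3-yl, without a step past the scatter (a 1.8-fold higher number from compound 3 to compound 4 (0.25 log units; within the scatter)). The new group also stands clear of carbamoylmethyl (a 2.3-fold lower number from compound 2 to compound 4 (0.36 log units; beyond the scatter)), but unlike oxetan-3-yl it does not separate from hydrogen on this nitrogen (a 1.6-fold lower number from compound 1 to compound 4 (0.20 log units; within the scatter)), so its advantage over the unsubstituted compound remains unshown. Nothing measured here offers an explanation for these steps.

The compounds shown leave open whether the acetyl group contributes at all, a question that the same four-membered ring bearing a free amine in place of the acetylated nitrogen would address. They also leave open how a carboxylic acid or a longer chain on this nitrogen would compare with these groups.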